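Amide nitrogen substituents across three measured analogues

The compounds below may be only part of what the source reports. "The series", "measured", "known", "first", "only" and "open" are said of these compounds alone.

Compound 1, `COc1ccc2c(=O)c(/C=C/C(=O)Nc3cc(C)ccc3C)coc2c1`: in a functional assay (QGY7701 cells, Homo sapiens) for inhibition, read by MTT assay, with a stated time of 48 h (on this read-out higher numbers stand for weaker inhibition and lower numbers for stronger inhibition), compound 1 gives > 100000 nM, a limit of the assay.
Compound 2, `COc1ccc2c(=O)c(/C=C/C(=O)NCc3ccc(F)cc3)coc2c1`: in this assay compound 2 gives 7960 nM.
Compound 3, `COc1ccc(NC(=O)/C=C/c2coc3cc(OC)ccc3c2=O)cc1`: in this assay compound 3 gives > 100000 nM, again a limit.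

Compound 3 thus stands at the limit, not at a number. The limit recurs: the limit of > 100000 nM in this assay, at which 2 of the 3 values shown sit. Going by the values given here, the step of an at least 12-fold higher number from compound 2 to compound 3 (1.09 log units; beyond the scatter) is the only readable one touching compound 3; the step that the two limits leave unreadable from compound 1 to compound 3 cannot be sized. Compound 4, `COc1ccc2c(=O)c(/C=C/C(=O)Nc3ccc(F)cc3)coc2c1`, differs from compound 3 by fluoro in place of methoxy on an aromatic carbon. The 4-fluorophenyl of compound 4 keeps the aryl amide pattern of compounds 1 and 3, both at the limit, rather than the 4-fluorobenzyl of compound 2. Compound 4 is therefore expected to give a number near or at the limit, 80000 nM (20000 nM to 300000 nM). This estimate means the step of an at least 1.2-fold lower number from compound 3 to compound 4 (0.09 log units; that floor lies within the scatter), expected to be small.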

Compound 4, half-maximal inhibitory concentration: > 100000 nM
Compound 4 gave a limit, no number; the forecaster's own chance of this, stated with the estimate: 60%; at least 1.2-fold (0.09 log units) between middle value and limit.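

In this assay compound 4 gives > 100000 nM, a limit of the assay and not a number. With the fluoro kept, 4-fluorophenyl in place of 4-fluorobenzyl gives an at least 12-fold higher number from compound 2 to compound 4 (1.09 log units; beyond the scatter), so the fluoro alone does not carry the measurable value of compound 2. The steps to compound 4 from compound 1 and compound 3 join two limits and cannot be read: the limit of > 100000 nM in this assay, at which 3 of the 4 values shown sit.

As far as these compounds go, what a longer chain on the amide nitrogen, such as 2-phenylethyl, would give remains open. Also open, from the compounds shown here alone, is whether methoxy in place of fluoro on the benzyl group of compound 2 would move its number.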